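Swapping morpholine for methylpiperidine on the shared amide core

The source may hold more compounds than are shown below. What is called first, only, known or untested is meant among the compounds shown, and "the series" means these compounds.

Measured compounds:
compound 1 `N#CC1(NC(=O)[C@@H]2C[C@@H](S(=O)(=O)c3ccccc3)C[C@H]2C(=O)N2CCOCC2)CC1`, 12 nM
compound 2 `N#CC1(NC(=O)[C@@H]2C[C@@H](S(=O)(=O)c3ccccc3)C[C@H]2C(=O)N2CCOCC2)CCC1`, 236 nM

In a functional assay on A20 cells (Mus musculus) for inhibition, with stated times of 1 h, 16 h and 24 h (on this read-out lower numbers stand for stronger inhibition and higher numbers for weaker inhibition), compound 1 gives 12 nM, the lowest number of the two measured compounds; compound 2 gives 236 nM, and the step of a 20-fold higher number from compound 1 to compound 2 (1.29 log units; beyond the scatter) is large. That step changes a different part of the molecule, the group on the amide-type nitrogen, so it says nothing direct about the change considered here.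

Compound 3 `CC1CCN(C(=O)[C@@H]2C[C@H](S(=O)(=O)c3ccccc3)C[C@H]2C(=O)NC2(C#N)CC2)CC1` differs from compound 1 by 4-methylpiperidin-1-yl in place of morpholin-4-yl on a carbonyl carbon. No measured step touches this carbonyl-bound ring, so the expectation rests only on the two compounds shown and on the size of the change. A modest step is expected, a 1.7-fold higher number from compound 1 to compound 3 (0.22 log units; within the scatter), most likely within or near the scatter. Compound 3 is therefore estimated to give 20 nM, with a range from 5 nM to 80 nM.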

Compound 3, half-maximal inhibitory concentration: 2 nM
Beside the measured number, compound 3's estimate is 10-fold (1.00 log units) above it, and the stated range ends above it.
By their numbers in this assay, from the lowest: compound 3; then compound 1; then compound 2.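

In this assay, 4-methylpiperidin-1-yl in place of morpholin-4-yl on a carbonyl carbon gives a 6.0-fold lower number from compound 1 to compound 3 (0.78 log units; beyond the scatter) and so a change beyond the usual scatter. Until now, only the group on the amide-type nitrogen had been seen to move this number, whereas this result shows that the ring on the carbonyl carbon matters too, and that here the ring without oxygen and with a methyl group gives the lower number. No supporting data on the cause of this step are available here.

Going by these compounds, the swap alters two things at once, the ring oxygen and the added methyl, so their separate shares remain unknown. Plain piperidin-1-yl on the same carbonyl carbon would help separate them, and whether the gain also holds with 1-cyanocyclobutyl on the amide-type nitrogen stays open.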